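Aryl substituent variation on the saturated ring carbon

The compounds below may be only part of what the source reports. "The series", "measured", "known", "first", "only" and "open" are said of these compounds alone.

All numbers below come from a functional assay on Ehrlich cells (Mus musculus) for cytotoxicity, read by trypan blue exclusion, with a stated time of 2 h, tested at 100 ug/mL; on this read-out higher numbers stand for a stronger effect at the one concentration tested and lower numbers for a weaker effect.

compound 1 `Cc1ccc(C2C(C#N)=C(N)N(c3ccc(S(N)(=O)=O)cc3)C3=C2CCCC3)cc1` gives 90%
compound 2 `N#CC1=C(N)N(c2ccc(S(N)(=O)=O)cc2)C2=C(CCCC2)C1/C=C/c1ccccc1` gives 70%
compound 3 `COc1ccc(C2C(C#N)=C(N)N(c3ccc(S(N)(=O)=O)cc3)C3=C2CCCC3)cc1` gives 100%

Compound 3 holds the highest number of the three, but compound 1 sits within the scatter of it, so the two cannot be ranked; only compound 2 stands apart, a number 30 percentage points higher from compound 2 to compound 3 (beyond the scatter). The two steps that are beyond the scatter, a number 20 percentage points lower from compound 1 to compound 2 (beyond the scatter) and a number 30 percentage points higher from compound 2 to compound 3 (beyond the scatter), both involve the exchange of a 2-phenylethenyl group for a substituted phenyl on the saturated ring carbon. Within the data shown here, the one step that changes the group on the aromatic carbon, a number 10 percentage points higher from compound 1 to compound 3 (within the scatter), stays within the scatter.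

Compound 4 `N#CC1=C(N)N(c2ccc(S(N)(=O)=O)cc2)C2=C(CCCC2)C1c1ccc([N+](=O)[O-])cc1` is the next member. (nitro in place of methoxy on an aromatic carbon). Among the measured compounds shown here, the only comparable change is the one from compound 1 to compound 3, which bears directly on this step: a substituent exchange on the same aromatic carbon, and it produced no step beyond the scatter. On that basis no step beyond the scatter is expected for compound 4 in this assay; the expected step is a number 5 percentage points lower from compound 3 to compound 4 (within the scatter). Compound 4 is therefore estimated at 95%, with a range from 75% to 100%, the upper end being the ceiling of the read-out.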

Compound 4, a percentage reported as activity, at one concentration (the size of the read-out at that concentration, not a potency): 20%
Beside the measured number, compound 4's estimate is 75 percentage points above it, outside the stated range (below it).
By their numbers in this assay, from the lowest: compound 4; then compound 2; then compounds 1 and 3 (each within the scatter of the next).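

In this assay, the aromatic carbon carrying the methyl or methoxy group proves sensitive to the choice of substituent: nitro in place of methoxy gives a number 80 percentage points lower from compound 3 to compound 4 (beyond the scatter), and nitro in place of methyl gives a number 70 percentage points lower from compound 1 to compound 4 (beyond the scatter), whereas methoxy in place of methyl gave a number 10 percentage points higher from compound 1 to compound 3 (within the scatter). The 4-nitrophenyl group also falls short of the 2-phenylethenyl group on the saturated ring carbon, with a number 50 percentage points lower from compound 2 to compound 4 (beyond the scatter), so a change within the substituted phenyl group can outweigh the exchange of that whole group seen earlier, and compound 4 stands apart from the other three at the low end of the series. Nothing available explains the size of this loss.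

The compounds shown leave open whether the loss is peculiar to nitro or is shared by other groups on the same aromatic carbon, such as an amine, a carboxylic acid, a chlorine atom or a longer alkoxy chain. With readings at one concentration only, they also leave open how the four compounds would rank in potency, especially compounds 1 and 3, which cannot be separated here.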